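Turning one stereocentre from S to R

This account rests on a few compounds, and the source may have more. Where it says the series, first, only, none or still open, it means among the compounds named here.

Measured so far in a functional assay on BXPC-3 cells (Homo sapiens) for cytotoxicity, read by MTT assay, with a stated time of 72 h; a higher number here means a weaker inhibitor, a lower number a stronger inhibitor
- compound 1 `COc1ccc(C(CC(=O)N[C@@H](CC(C)C)B(O)O)NC(=O)c2ccccc2)cc1` gives 1500 nM in this read-out
- compound 2 `COc1ccc([C@H](CC(=O)N[C@@H](CC(C)C)B(O)O)NC(=O)c2ccccc2)cc1` gives 2820 nM in this read-out

Compound 2 stands level with compound 1 on these numbers. Going by the values given here, the only measured step is a 1.9-fold higher number from compound 1 to compound 2 (0.27 log units; within the scatter) and it lies within the scatter. That step concerns a single stereocentre at a saturated chain carbon, drawn without a configuration in compound 1 and S in compound 2.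

Among the compounds with values here, compound 3 `COc1ccc([C@@H](CC(=O)N[C@@H](CC(C)C)B(O)O)NC(=O)c2ccccc2)cc1` takes the other configuration at that centre (the two compounds have the same atoms and bonds and differ only in configuration as drawn: 1 of 2 stereo elements differ; a stereocentre at a saturated chain carbon is drawn S in compound 2 and R in compound 3), so no measured step tests this change directly. The step above bears on it only indirectly. If compound 1 holds both configurations, its 1500 nM would be a blend of two forms, and compound 3 would then be expected to give a modestly lower number than compound 2 in this assay. Since that hint rests on a step within the scatter, it is weak and the range must stay wide. The estimated move is a 2.6-fold lower number from compound 2 to compound 3 (0.41 log units; beyond the scatter) and it may not clear the scatter. Compound 3 is therefore estimated at 1100 nM with a range from 350 nM to 3500 nM as the expected span.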

Compound 3, half-maximal inhibitory concentration: 380 nM
Estimate against measurement, compound 3: 2.9-fold (0.46 log units) above, within the range that was stated.
By their numbers in this assay, from the lowest: compound 3; then compounds 1 and 2 (each within the scatter of the next).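

In this assay, the R configuration at this saturated chain carbon gives the strongest of the three compounds, with a 7.4-fold lower number from compound 2 to compound 3 (0.87 log units; beyond the scatter), and this gap can be tied to configuration alone because nothing else separates the two structures: the fact that compounds 2 and 3 differ only in the configuration as drawn

The second comparison points the same way, with a 3.9-fold lower number from compound 1 to compound 3 (0.60 log units; beyond the scatter), whereas the earlier step at this centre lay within the scatter and could not show whether configuration mattered here. The position is therefore sensitive to configuration in this assay, with R ahead of S, although this has been shown on a single set of substituents and so stands as a finding about these compounds, not as a general rule.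

The compounds shown do not settle whether compound 1 holds both configurations or in what proportion, nor what the second stereocentre, drawn alike in all three, contributes. They also leave open whether R would keep its lead on the shared core if it carried a carboxylic acid, an amine or a longer chain.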